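The source may report more compounds than this note shows. Statements on the series, on what has been measured and on what is new or still open speak of the compounds shown alone.

Among the measured compounds shown here, compound 2 `Cn1c(Cc2cccnc2)nc2cc(O[C@H]3CC[C@@H](C(=O)O)CC3)ccc21` stands highest of the two numbers measured so far: in an assay on isolated protein for inhibition of Long-chain-fatty-acid--CoA ligase 1 (Homo sapiens), read by mass spectrometry, with a stated time of 90 min, in the presence of a further agent that is not named here (on this read-out lower numbers stand for stronger inhibition and higher numbers for weaker inhibition), compound 2 gives 141000 nM. For the measured compounds named here, its only neighbour, compound 1 `Cn1c(Cc2cccc(C#N)c2)nc2cc(O[C@H]3CC[C@@H](C(=O)O)CC3)ccc21`, gives 51000 nM in this assay, and a 2.8-fold higher number from compound 1 to compound 2 (0.44 log units; beyond the scatter) is the single measured step in the set. Compound 3 `Cc1cccc(Oc2nc3cc(O[C@H]4CC[C@@H](C(=O)O)CC4)ccc3n2C)c1` differs from compound 2 by 3-methylphenoxy in place of (pyridin-3-yl)methyl on an aromatic carbon. Going by the values given here, no measured step covers this exchange; the step of a 2.8-fold higher number from compound 1 to compound 2 (0.44 log units; beyond the scatter) only shows that a carbon-only aromatic ring on this arm went with the lower number, so compound 3 is expected to move back in that direction, a 2.8-fold lower number from compound 2 to compound 3 (0.45 log units; beyond the scatter), with wide uncertainty since the attachment also changes. Compound 3 is estimated at 50000 nM, between 15000 nM and 160000 nM.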

Compound 3, half-maximal inhibitory concentration: 78000 nM
For compound 3 the middle estimate is 1.6-fold (0.19 log units) below the measured one; measured number inside the range.
By their numbers in this assay, from the lowest: compounds 1, 3 and 2 (each within the scatter of the next, the first and the last beyond it).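

At this aromatic carbon between two ring nitrogen atoms, the ether-linked 3-methylphenoxy arm does not separate from either carbon-linked arm: the data give a 1.8-fold lower number from compound 2 to compound 3 (0.26 log units; within the scatter) and also a 1.5-fold higher number from compound 1 to compound 3 (0.18 log units; within the scatter) for the exchange. Compound 3 thus lies within the scatter of both compounds, even though those two differ beyond it. Nothing available accounts for these values.

Compound 3 changes the linking atom and the ring together, so their separate contributions remain unresolved. Also open, on these data alone, is how an amine linking the ring at this carbon, or a longer chain, would read.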